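Adding a hydroxy group to compound 1

This account rests on a few compounds, and the source may have more. Where it says the series, first, only, none or still open, it means among the compounds named here.

In a functional assay on PANC-1 cells (Homo sapiens) for antiproliferative activity, read by fluorescence and resazurin assay, with a stated time of 48 h (a lower number here means a stronger inhibitor, a higher number a weaker inhibitor), compound 1 (`CCOc1ccc2nc(Cl)c(/C=N/NC(=O)c3cc4ccccc4oc3=O)cc2c1`) gives 29900 nM. Within the data shown here, only one other number is available for comparison: compound 2 (`CCOc1ccc2nc(Cl)c(/C=N/NC(=O)c3cc4cc(Br)ccc4oc3=O)cc2c1`) gives 17000 nM. Among the measured compounds shown here, the measured step, a 1.8-fold lower number from compound 1 to compound 2 (0.25 log units; within the scatter), does not separate the two values, so compound 1 stands level with its only neighbour.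

Compound 3 (`CCOc1ccc2nc(Cl)c(/C=N/NC(=O)c3cc4ccc(O)cc4oc3=O)cc2c1`) keeps the core of compound 1 and differs by a single change: hydroxy in place of hydrogen on an aromatic carbon. For the measured compounds named here, no measured compound carries a hydroxy group, so the data offer no direct precedent. The closest evidence is the bromo group of compound 2, which also replaces hydrogen on an aromatic carbon, though a single case sets no rule. Going by the values given here, with a 1.8-fold lower number from compound 1 to compound 2 (0.25 log units; within the scatter) as the only guide, no step beyond the scatter is expected in this assay, with only a slight lean towards a lower number.

For compound 3, the estimated value is 22000 nM, with an expected range from 9000 nM to 50000 nM. This estimate corresponds to an expected step of a 1.4-fold lower number from compound 1 to compound 3 (0.13 log units; within the scatter).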

Compound 3, half-maximal inhibitory concentration: 129 nM
Compound 3: middle estimate off by 170-fold (2.23 log units), on the high side; the whole stated range lies above it.
By their numbers in this assay, from the lowest: compound 3; then compounds 2 and 1 (each within the scatter of the next).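

In this assay, hydroxy in place of hydrogen on this aromatic carbon, in a fused system of two rings, gives a 230-fold lower number from compound 1 to compound 3 (2.37 log units; beyond the scatter) and shows that the core of compound 1 can respond strongly to a single added heavy atom. Among these compounds, the only earlier step, a 1.8-fold lower number from compound 1 to compound 2 (0.25 log units; within the scatter) and within the scatter, gave no sign of such sensitivity, so replacing an aromatic hydrogen does not by itself produce a large change across these compounds. The data available here offer no measurement that bears on the reason for this large step.

Still open, as far as these compounds go, is whether the step belongs specifically to the hydroxy group or would also appear with a methoxy group, an amine or a carboxylic acid on the same aromatic carbon. Also open, from the compounds shown here alone, is whether a hydroxy group on another carbon of the same ring would give a step of similar size, which would show how far the result depends on the group and how far on its place.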